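Working notes on a cytotoxicity series, compounds 1 to 4

The source may report more compounds than this note shows. Statements on the series, on what has been measured and on what is new or still open speak of the compounds shown alone.

Measured so far:
compound 1 `CC1=NN(C(=O)COc2ccc(Cl)cc2)C(c2ccccc2O)C1` gives "not active" (no number reported) in a functional assay on MGC-803 cells (Homo sapiens) for cytotoxicity, read by MTT assay, with a stated time of 48 h; on this read-out higher numbers stand for weaker inhibition and lower numbers for stronger inhibition.
compound 2 `CC(=O)Oc1ccccc1C1CC(C)=NN1C(=O)CN1CCCCC1` gives 4890 nM in this assay.
compound 3 `CCC(=O)N1N=C(c2cc3ccccc3oc2=O)CC1c1ccccc1` gives 5300 nM in this assay.

Among the compounds with values here, only two numbers exist in this assay, those of compound 2 and compound 3; they lie within the usual scatter of each other, so neither can be called stronger or weaker, and compound 1 gives no number at all. Within the data shown here, no pair of measured compounds differs in a single place, so no step within the measured set is known.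

Compound 4 `O=C(CN1CCC(O)CC1)N1N=C(c2cc3ccccc3oc2=O)CC1c1ccccc1` has not yet been measured in this assay. Against compound 3 the change is 4-hydroxypiperidin-1-yl in place of methyl on a saturated chain carbon bound to a carbonyl carbon. Compound 2 also carries a ring with one nitrogen at the chain carbon bound to the carbonyl, but differs from compound 3 in more than one place, so its value is noted only as context.

Among the measured compounds shown here, no isolated step for this change is available; a small gain is expected, with the step of a 1.5-fold lower number from compound 3 to compound 4 (0.18 log units; within the scatter) near the edge of the scatter. Compound 4 is expected to give 3500 nM, within 1200 nM to 10000 nM.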

Compound 4, half-maximal inhibitory concentration: "not active" (no number reported)
For compound 4 the study gives words and no number; there is nothing to compare the estimate with.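

No step can be read from compound 3 to compound 4, since in this assay compound 4 gives "not active" (no number reported) and so offers no number to compare. Nothing shown bears on the cause of this result. The compounds shown leave open how other groups at this place on the saturated chain carbon would read out in this assay.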